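A few compounds are considered here, and "the series" means these few. Any claim that something is new, unique, unknown or untested is made for them only; others in the source may bear on it.

Measured in a functional assay on HCC 2998 cells (Homo sapiens) for antiproliferative activity; on this read-out higher numbers stand for weaker inhibition of growth and lower numbers for stronger inhibition of growth:
- compound 1 `COc1ccc(-c2nc3ccccc3s2)cc1OC`: 42500 nM
- compound 2 `COc1ccc(-c2nc3ccc(F)cc3s2)cc1OC`: 6210 nM

Of these two, compound 1 stands highest at 42500 nM, so it shows the weaker inhibition of growth. Compound 3 `COc1ccc(-c2nc3c(F)cccc3s2)cc1OC` differs from compound 1 by fluoro in place of hydrogen on an aromatic carbon, ortho to a fused ring and meta to a fused ring.

For the measured compounds named here, only one measured step bears on this change: a 6.8-fold lower number from compound 1 to compound 2 (0.84 log units; beyond the scatter). It is the same kind of replacement, made at a different aromatic carbon. This single step shows no pattern, and nothing measured yet shows how the placement of the fluoro alters the read-out. A lower number is therefore expected in this assay, with a step of modest size and less certain than the measured one.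

The expected step is a 2.8-fold lower number from compound 1 to compound 3 (0.45 log units; beyond the scatter).

For compound 3 the estimated value is 15000 nM, with an expected range of 4000 nM to 45000 nM.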

Compound 3, concentration for 50% growth inhibition: 1060 nM
For compound 3 the middle estimate is 14-fold (1.15 log units) above the measured one; measured number outside the range, below it.
By their numbers in this assay, from the lowest: compound 3; then compound 2; then compound 1.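

In this assay, fluoro in place of hydrogen on the aromatic carbon ortho to a fused ring and meta to a fused ring gives a 40-fold lower number from compound 1 to compound 3 (1.60 log units; beyond the scatter), a large step. The same replacement at a different aromatic carbon gives only a modest step, a 6.8-fold lower number from compound 1 to compound 2 (0.84 log units; beyond the scatter), so in this pair of compounds the size of the gain depends on where the fluoro sits, not just on its presence. No measurement available here accounts for this difference in step size.

On these data alone, it remains open whether this carbon favours fluoro specifically or whether a chloro, a methoxy or an amine at the same place would also lower the number. Also open, as far as these compounds go, is whether the two fluoro placements would add up if combined on the core of compound 1.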